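Trimming Two Methyls from a Thiophene Ring

A few compounds are considered here, and "the series" means these few. Any claim that something is new, unique, unknown or untested is made for them only; others in the source may bear on it.

Compound 1, `Cc1cc(-c2nc3sc(C)cn3c2/C=N/NC(=N)N)c(C)s1`: 32400 nM
Compound 2, `Cc1cn2c(/C=N/Nc3ccccn3)c(-c3ccc(Cl)c([N+](=O)[O-])c3)nc2s1`: 39800 nM

Of the compounds shown here, two have been measured in a functional assay on cells (Cancer cell lines, Homo sapiens) for inhibition; on this read-out higher numbers stand for weaker inhibition of growth and lower numbers for stronger inhibition of growth. Compound 1 gives 32400 nM, and compound 2 gives 39800 nM; the gap between them lies within the usual scatter, so neither can be called the stronger inhibitor. Compound 1 is the starting point for the next comparison. The new compound, compound 3, `Cc1cn2c(/C=N/NC(=N)N)c(-c3ccsc3)nc2s1`, differs from it in a single place: thiophen-3-yl in place of 2,5-dimethylthiophen-3-yl on an aromatic carbon. For the measured compounds named here, no measured pair in this set shows what removing such methyl groups does on this scaffold, so there is no direct precedent. The expectation is therefore a step of no more than the scatter, a 1.3-fold higher number from compound 1 to compound 3 (0.11 log units; within the scatter), with a slight lean toward weaker inhibition. Compound 3 is expected to give about 42000 nM in this assay, in a range from 12000 nM to 150000 nM.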

Compound 3, concentration for total growth inhibition: 28200 nM
For compound 3 the middle estimate is 1.5-fold (0.17 log units) above the measured one, within the range that was stated.
By their numbers in this assay, from the lowest: compounds 3, 1 and 2 (each within the scatter of the next).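

In this assay, thiophen-3-yl in place of 2,5-dimethylthiophen-3-yl gives a 1.1-fold lower number from compound 1 to compound 3 (0.06 log units; within the scatter) on the shared core. For the compounds shown here, this is the first direct comparison in the set, and it shows that the two methyl groups on the thiophene can be removed together without a readable change in growth inhibition. Nothing measured here bears on why the read-out stays within the scatter.

Because both methyl groups leave in a single step, these compounds cannot show what either one does alone. From the compounds shown here alone, it also remains open whether this aromatic carbon would keep the read-out within the scatter if it carried a larger change, such as a thiophene bearing a carboxylic acid or an amine, or a longer chain in place of the thiophene.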